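A few compounds are considered here, and "the series" means these few. Any claim that something is new, unique, unknown or untested is made for them only; others in the source may bear on it.

Measured in a functional assay on HaCaT cells (Homo sapiens) for antiproliferative activity, read by sulforhodamine B assay, with a stated time of 3 days; a lower number here means a stronger inhibitor, a higher number a weaker inhibitor:
- Compound 1 `COC(=O)c1cc(CCc2ccccc2OC)ccc1O`: 20000 nM
- Compound 2 `COC(=O)c1cc(CCc2cc(O)ccc2OC)ccc1O`: 8700 nM
- Compound 3 `COC(=O)c1cc(CCc2cc(O)ccc2O)ccc1O`: 21000 nM

Compound 2 has the lowest number of the three. Compound 4 `CCOc1ccc(OC)c(CCc2ccc(O)c(C(=O)OC)c2)c1` differs from it by ethyl in place of hydrogen on an oxygen on an aromatic ring, so hydroxy becomes ethoxy. Going by the values given here, no measured step changes this hydroxy directly. The closest evidence is a 2.3-fold lower number from compound 1 to compound 2 (0.36 log units; beyond the scatter), where the same hydroxy arrives. The other step, a 2.4-fold higher number from compound 2 to compound 3 (0.38 log units; beyond the scatter), removes a methyl from a different oxygen. Both steps are modest, so a modest rise in this assay is expected, though it could stay within the scatter. The expected change is a 1.4-fold higher number from compound 2 to compound 4 (0.14 log units; within the scatter). For compound 4 the estimated value is 12000 nM, with an expected range of 5000 nM to 28000 nM.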

Compound 4, half-maximal inhibitory concentration: 540 nM
The estimate for compound 4 lay 22-fold (1.35 log units) above the measured number, outside the stated range (below it).
By their numbers in this assay, from the lowest: compound 4; then compound 2; then compounds 1 and 3 (each within the scatter of the next).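

In this assay, going by these compounds alone, ethyl on this oxygen on an aromatic ring produces a large step (a 16-fold lower number from compound 2 to compound 4 (1.21 log units; beyond the scatter)), while the earlier steps were all modest. Set against the compound with hydrogen on that aromatic carbon, ethoxy (a 37-fold lower number from compound 1 to compound 4 (1.57 log units; beyond the scatter)) goes far beyond what hydroxy gave there (a 2.3-fold lower number from compound 1 to compound 2 (0.36 log units; beyond the scatter)), so this position can move the number much more than the earlier compounds showed. Nothing measured here accounts for the size of this change. The compounds shown leave open whether a propoxy group, a longer chain or an amine at this place would keep the number this low.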